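The source may report more compounds than this note shows. Statements on the series, on what has been measured and on what is new or still open speak of the compounds shown alone.

Measured so far in a physicochemical assay for solubility, read by HPLC; on this read-out lower numbers stand for lower solubility and higher numbers for higher solubility:
- compound 1 `O=C1NCc2ncc(-c3ccc(-c4cncc(NS(=O)(=O)c5ccc(F)cc5F)c4)s3)cc21`: 3770 ug/mL
- compound 2 `COc1ncc(-c2ccc(-c3cnc4c(c3)CN(C)C4=O)s2)cc1NS(=O)(=O)c1ccc(F)cc1F`: 18300 ug/mL

Of these two numbers, compound 1 holds the lower one, and the gap to compound 2 lies beyond the scatter. Going by the values given here, the two compounds differ in more than one place, so their values give no step for a single change.

Compound 3 `O=C1NCc2cc(-c3ccc(-c4cncc(NS(=O)(=O)c5ccc(F)cc5F)c4)s3)cnc21` is not yet measured. It has the same atoms as compound 1, joined differently: a group of 10 heavy atoms (7 carbon, 2 nitrogen, 1 oxygen; one five-membered non-aromatic ring with 1 hetero atom, one six-membered aromatic ring with 1 hetero atom) in place of a group of 10 heavy atoms (7 carbon, 2 nitrogen, 1 oxygen; one five-membered non-aromatic ring with 1 hetero atom, one six-membered aromatic ring with 1 hetero atom), on an aromatic carbon. Among the compounds with values here, the group that enters matches the one that leaves in every counted feature, and no measured pair shows what such a rearrangement does in this assay.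

Within the data shown here, with no such pair, no step beyond the scatter is expected in either direction, and the expectation stays anchored on compound 1 at 3770 ug/mL. The estimated change is a 1.1-fold higher number from compound 1 to compound 3 (0.03 log units; within the scatter). For compound 3 the estimate is 4000 ug/mL, with an expected range of 1300 ug/mL to 12500 ug/mL.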

Compound 3, solubility: 1130 ug/mL
Estimate against measurement, compound 3: 3.5-fold (0.55 log units) above; the measured number lies below the stated range.
By their numbers in this assay, from the lowest: compound 3; then compound 1; then compound 2.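

In this assay, going by these compounds alone, moving the atoms within the group on the aromatic carbon next to the ring sulfur gives a 3.3-fold lower number from compound 1 to compound 3 (0.52 log units; beyond the scatter), the first single-place step. Every feature counted for the group is the same on both sides, so at this position the read-out separates two arrangements that those counts do not distinguish. Nothing measured here gives a reason for the step.

The compounds shown leave open whether compound 3 would stay under compound 1 if a further group, such as a dimethylamino group or a carboxylic acid, were carried on the rearranged group. Within the data shown here, they also leave open which of the several differences in compound 2 goes with its 18300 ug/mL reading, since no single-place step connects it to either neighbour.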